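The source may hold more compounds than are shown below. What is called first, only, known or untested is meant among the compounds shown, and "the series" means these compounds.

Among the measured compounds shown here, the three compounds measured so far share one core and differ at the two aryl positions. Compound 1 `O=C(N/N=C/c1ccco1)c1cc(-c2ccccc2)nn1Cc1ccc(Cl)nc1` gives 19400 nM in a physicochemical assay on A549 cells for solubility, read by microscopy, with a stated time of 24 h; a lower number here means a stronger inhibitor, a higher number a weaker inhibitor. Compound 2 `O=C(N/N=C/c1ccco1)c1cc(-c2ccc(Cl)cc2)nn1Cc1ccc(Cl)nc1` gives 9820 nM in this assay, and the change from compound 1 to compound 2 is a 2.0-fold lower number from compound 1 to compound 2 (0.30 log units; within the scatter), a chloro in place of hydrogen on an aromatic carbon. Compound 3 `COc1ccc(/C=N/NC(=O)c2cc(-c3ccc(OC)cc3)nn2Cc2ccc(Cl)nc2)cc1` gives 18900 nM in this assay, which places it second highest of the three numbers, within the scatter of compound 1 and also within the scatter of compound 2.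

Compound 4 `COc1ccc(-c2cc(C(=O)N/N=C/c3ccco3)n(Cc3ccc(Cl)nc3)n2)cc1` differs from compound 3 in one place: furan-2-yl in place of 4-methoxyphenyl on a carbon with a double bond to nitrogen. For the measured compounds named here, no measured pair shows this change, so the single measured step, from compound 1 to compound 2, does not bear on it directly. What the data do show is that compound 1, which carries furan-2-yl at that carbon, and compound 3, which carries 4-methoxyphenyl there, give numbers within the scatter of each other. On that basis compound 4 is expected to sit close to compound 3, with a step of a 1.2-fold lower number from compound 3 to compound 4 (0.07 log units; within the scatter) that is expected to stay within the scatter. The estimate for compound 4 in this assay is 16000 nM, expected to fall between 7000 nM and 36000 nM.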

Compound 4, half-maximal inhibitory concentration: 15800 nM
Estimate against measurement, compound 4: 1.0-fold (0.01 log units) above; the range from low to high includes it.
By their numbers in this assay, from the lowest: compounds 2, 4, 3 and 1 (each within the scatter of the next).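

In this assay the change to furan-2-yl from 4-methoxyphenyl, on a carbon with a double bond to nitrogen, now has a measured pair of its own, and it gives a 1.2-fold lower number from compound 3 to compound 4 (0.08 log units; within the scatter) with the rest of the structure held the same. On the aromatic carbon, methoxy in place of chloro gives a 1.6-fold higher number from compound 2 to compound 4 (0.21 log units; within the scatter) and methoxy in place of hydrogen gives a 1.2-fold lower number from compound 1 to compound 4 (0.09 log units; within the scatter) as well, so neither change separates these compounds beyond the scatter. Nothing measured here gives a reason for these steps.

The compounds shown leave open whether any group at either place can produce a step beyond the scatter. An amine or a carboxylic acid on the aromatic carbon, or a longer chain on the carbon with a double bond to nitrogen, would test this.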